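Chloro in Place of Fluoro on the Core of Compound 1

This account rests on a few compounds, and the source may have more. Where it says the series, first, only, none or still open, it means among the compounds named here.

Compound 1 `Cc1cc(-c2nc3cc(F)ccc3o2)ccc1NC(=O)CN1CCN(CCN(C)C)CC1` is tested in a functional assay on HT-29 cells (Homo sapiens) for cytotoxicity, read by MTT assay, with a stated time of 24 h (on this read-out lower numbers stand for stronger inhibition and higher numbers for weaker inhibition), where compound 1 gives 6600 nM. Compound 3 `Cc1cc(-c2nc3cc(F)ccc3o2)ccc1NC(=O)CN1CCN(CCCN(C)C)CC1` gives 6700 nM, and compound 2 `CN(C)CCCN1CCN(CC(=O)Nc2ccc(-c3nc4ccccc4o3)cc2)CC1` gives 10600 nM. Compound 1 has the lowest of the three numbers, but both other values lie within the scatter of it, so the three cannot be told apart. For the measured compounds named here, the only measured step, a 1.0-fold higher number from compound 1 to compound 3 (0.01 log units; within the scatter), changes the chain and leaves the ring untouched. Compound 4 `Cc1cc(-c2nc3cc(Cl)ccc3o2)ccc1NC(=O)CN1CCN(CCN(C)C)CC1` differs from compound 1 by chloro in place of fluoro on an aromatic carbon. No measured step concerns this halogen, so nothing shown argues for a shift in either direction. The expected step is therefore a 1.1-fold lower number from compound 1 to compound 4 (0.04 log units; within the scatter), which is nothing beyond the scatter. Compound 4 is estimated at 6000 nM, between 2500 nM and 15000 nM.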

Compound 4, half-maximal inhibitory concentration: 13200 nM
Compound 4: middle estimate off by 2.2-fold (0.34 log units), on the low side; the measured number falls inside the stated range.
By their numbers in this assay, from the lowest: compounds 1, 3, 2 and 4 (each within the scatter of the next).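

In this assay the halogen on the shared core gives a 2.0-fold higher number from compound 1 to compound 4 (0.30 log units; within the scatter) and so compound 1 and compound 4 cannot be told apart, which means that at this position, chloro in place of fluoro has not produced a difference that can be separated from repeat-measurement noise. No outside measurement bears on this result. On these data alone, whether bromo or a methoxy group at this position would stand apart from fluoro and chloro remains open, as does whether chloro would read the same on the longer chain of compound 3.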